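This account rests on a few compounds, and the source may have more. Where it says the series, first, only, none or still open, it means among the compounds named here.

Measured in an ADME assay on J774 cells (Mus musculus) for antiproliferative activity, with a stated time of 72 h; a higher number here means that more compound is needed for the effect, a lower number that less compound is needed:
Compound 1 `CCCCc1cc2c(=O)cc(C)[nH]c2cc1OCCOc1ccccc1`: 28000 nM
Compound 2 `CCc1c(C)[nH]c2cc(OCCOc3ccccc3)c(Cl)cc2c1=O`: > 28000 nM (a limit of the assay)

Among the measured compounds in this assay, compound 1 is the only one with an exact value, 28000 nM. Compound 2 has only a limit, > 28000 nM. The record therefore consists of one number and (the limit of > 28000 nM in this assay, at which 1 of the 2 values shown sits).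

Compound 3 `CCCCc1cc2c(=O)c(-c3ccc(C(F)(F)F)cc3)c(C)[nH]c2cc1OCCOc1ccccc1` keeps the core of compound 1 and differs from it in one place: 4-(trifluoromethyl)phenyl in place of hydrogen on an aromatic carbon. A 4-(trifluoromethyl)phenyl stands in place of hydrogen on an aromatic carbon of the six-membered aromatic ring with 1 nitrogen, ortho to a methyl group.

Among the measured compounds shown here, no pair of measured compounds shows a comparable single change, so the data give no direct measure of this step. The expectation rests on compound 1 at 28000 nM, and no shift beyond the usual scatter is expected in this assay. The expected change is a 1.3-fold lower number from compound 1 to compound 3 (0.10 log units; within the scatter). Compound 3 could also return only a limit. Compound 3 is estimated at 22000 nM, with an expected range of 7000 nM to 40000 nM.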

Compound 3, half-maximal effective concentration: 20000 nM
For compound 3 the middle estimate is 1.1-fold (0.04 log units) above the measured one; the range from low to high includes it.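

In this assay, putting 4-(trifluoromethyl)phenyl in place of hydrogen on this aromatic carbon, ortho to a methyl group and two atoms from the ring nitrogen, gives a 1.4-fold lower number from compound 1 to compound 3 (0.15 log units; within the scatter). Among the compounds shown here, this is the first direct reading at this position, and it shows that a group of 10 heavy atoms, with its own six-membered aromatic ring of carbon only, can stand there without a shift beyond the scatter. Compound 3 also returns an exact number, whereas compound 2 has only a limit of the assay, so the record now holds two exact values and this one limit: the limit of > 28000 nM in this assay, at which 1 of the 3 values shown sits.

The compounds shown leave open whether an amine, a carboxylic acid or an unsubstituted phenyl on this carbon would move the number beyond the scatter. For the compounds shown here, they also leave open whether 4-(trifluoromethyl)phenyl would give a similar step on a compound with a longer chain in place of the butyl group, since only this one step at this one position can be read.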